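A Longer Side Chain at the Limit of Measurement

A few compounds are considered here, and "the series" means these few. Any claim that something is new, unique, unknown or untested is made for them only; others in the source may bear on it.

In an in vitro ADME assay on microsomes from liver (Simiiformes) (on this read-out higher numbers stand for a longer-lived compound and lower numbers for a shorter-lived compound), compound 1 `COCc1cc(CCCOc2c(C)cc(-c3noc(C4CC4)n3)cc2C)on1` reads > 2.5 h as a limit and not a number. Compound 2 `Cc1cc(-c2noc(C3CC3)n2)cc(C)c1OCCCc1cc(C2CC2)no1` also reads > 2.5 h as a limit. Compound 3 `Cc1cc(-c2noc(C3CC3)n2)cc(C)c1OCCCc1cc(CO)no1` likewise stands only at a limit of > 2.5 h in this read-out. The series therefore offers one picture (the limit of > 2.5 h in this assay, at which 3 of the 3 values shown sit). Compound 4 `Cc1cc(-c2noc(C3CC3)n2)cc(C)c1OCCCc1cc(OCCO)no1` carries 2-hydroxyethoxy in place of hydroxymethyl on an aromatic carbon next to the ring nitrogen (2-hydroxyethoxy in place of hydroxymethyl on an aromatic carbon). Two measured changes on that carbon bear on this: a step that the two limits leave unreadable from compound 1 to compound 2 and a step that the two limits leave unreadable from compound 2 to compound 3. Neither gives a size to carry over, so no step beyond the scatter is expected in this assay and the estimated change is a step that the limit leaves unreadable from compound 3 to compound 4 in no set direction. Compound 4 is expected at 3 h with an estimated range of 1.5 h to 6 h and may well read as a limit again.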

Compound 4, half-life: > 2.5 h
Compound 4 gave a limit, no number (the forecaster's own chance of this, stated with the estimate: 70%); the middle value does not contradict the limit.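

Compound 4 joins compound 1, compound 2 and compound 3 at a limit, so no step among them can be read: the limit of > 2.5 h in this assay, at which 4 of the 4 values shown sit.

The compounds shown leave open how long any of them actually lasts in this assay, and whether the changes on that aromatic carbon make any difference there.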